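The source may hold more compounds than are shown below. What is called first, only, known or untested is meant among the compounds shown, and "the series" means these compounds.

Compound 1, `COc1cccc(N2C(=O)CS/C2=N\c2csc(-c3ccc(C)cc3)c2)c1`, in a functional assay on SW-620 cells (Homo sapiens) for cytotoxicity, read by MTT assay, with a stated time of 72 h (a higher number here means a weaker inhibitor, a lower number a stronger inhibitor), gives > 50000 nM, which is a limit of the assay and not a number. Compound 2, `COc1cccc(N2C(=O)CS/C2=N\c2csc(-c3ccc(Cl)cc3)c2)c1`, in this assay gives 33000 nM.

Compound 2 therefore holds the only number shown; the other value is a limit. The step from compound 1 to compound 2 is an at least 1.5-fold lower number from compound 1 to compound 2 (0.18 log units; that floor lies within the scatter), and since compound 1 sits at the limit of > 50000 nM in this assay, at which 1 of the 2 values shown sits, that step is a floor rather than a measured size.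

Compound 3, `COc1ccc(N2C(=O)CS/C2=N\c2csc(-c3ccc(Cl)cc3)c2)cc1OC`, differs from compound 2 by methoxy in place of hydrogen on an aromatic carbon. No measured step touches this change: the one step shown swaps chloro for methyl at a different place. With no guide, no step beyond the scatter is expected from compound 2 to compound 3 in this assay, in either direction; no change at the digits printed from compound 2 to compound 3 (within the scatter) is the expected step. Compound 3 is estimated at 33000 nM, within 10000 nM to 100000 nM.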

Compound 3, half-maximal inhibitory concentration: > 50000 nM
Compound 3: no number, only a limit (the forecaster's own chance of this, stated with the estimate: 35%); middle value at least 1.5-fold (0.18 log units) from the limit.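

In this assay compound 3 gives > 50000 nM, which is a limit of the assay and not a number. Placing a methoxy group on this aromatic carbon, ortho to a methoxy group and para to a large group, gives an at least 1.5-fold higher number from compound 2 to compound 3 (0.18 log units; that floor lies within the scatter), so this change brings no gain that can be seen here, while the true size of the step remains unknown. This is the first view of this position, and it adds a second compound at the same limit: the limit of > 50000 nM in this assay, at which 2 of the 3 values shown sit.

On these data alone, whether a different group at this position, such as an amine, a carboxylic acid or a longer chain, would give a lower number than compound 2 stays open. Also open, as far as these compounds go, is whether the methoxy group would have the same effect on the core of compound 1, which carries methyl in place of chloro.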